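A few compounds are considered here, and "the series" means these few. Any claim that something is new, unique, unknown or untested is made for them only; others in the source may bear on it.

Within the data shown here, compound 1, with the structure `CCN(CC)CCNC(=O)C1CC(C(CC)(CC)c2ccc(C#CC(C)(O)CC)c(C)c2)=CN1CC`, is one of two compounds measured so far in an assay on isolated protein for binding affinity to vitamin D3 receptor (Homo sapiens), read by fluorescence polarization, tested at 1 uM; on this read-out higher numbers stand for more inhibition at the one concentration tested (going by the name of the read-out) and lower numbers for less inhibition. In that assay compound 1 gives 59.2%, the higher of the two numbers. The other measured compound, compound 2, has the structure `CCN(CC)CCNC(=O)C1CC=C(C(CC)(CC)c2ccc(C#CC(O)C3CCCCC3)c(C)c2)N1CC` and gives 45.6% in this assay, a figure that lies lower than that of compound 1 by a margin beyond the usual scatter of this kind of measurement.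

Compound 3, with the structure `CCN(CC)CCNC(=O)C1CC(C(CC)(CC)c2ccc(/C=C/C(O)(CC)CC)c(C)c2)=CN1CC`, has not yet been measured in this assay. Its structure differs from that of compound 1 in one place: a group of 8 heavy atoms (7 carbon, 1 oxygen; no ring) in place of a group of 7 heavy atoms (6 carbon, 1 oxygen; no ring), on an aromatic carbon. The group that leaves carries a triple bond outside aromatic rings; the group that enters carries a double bond outside aromatic rings, and it is larger by one heavy atom, with one hydrogen-bond donor and one hydrogen-bond acceptor kept on both sides of the change.

Among the measured compounds shown here, with no measured step of this kind available for comparison, a step of a number 7.2 percentage points lower from compound 1 to compound 3 (within the scatter) is expected, leaving compound 3 close to compound 1 or somewhat lower. Compound 3 is therefore estimated at 52%, with a likely range from 30% to 72%.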

Compound 3, a percentage reported as inhibition, at one concentration (the size of the read-out at that concentration, not a potency): 65.5%
Estimate against measurement, compound 3: 13.5 percentage points below; the measured number falls inside the stated range.
By their numbers in this assay, from the lowest: compound 2; then compounds 1 and 3 (each within the scatter of the next).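

In this assay the step is a number 6.3 percentage points higher from compound 1 to compound 3 (within the scatter) and stays within the scatter, so on the aromatic carbon ortho to a methyl group and para to a large group, the group with a double bond outside aromatic rings reads level with the group with a triple bond. Both earlier compounds carried a triple bond at this place, so they could not show whether a number of this size depended on it; this one pair shows that the triple bond can be exchanged without a step beyond the scatter, even with the entering group larger by one heavy atom and the hydrogen-bond donor and acceptor counts kept. No measurement offered here speaks to why the two groups read alike.

Among these compounds, the single step joins the change of bond with the added heavy atom, so what each contributes alone stays unresolved, and a reading at one concentration gives no potency. Also open, going by these compounds, is how this assay would respond at this place to a fully saturated chain, or to an amine or a carboxylic acid in place of the hydroxyl group.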